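The compounds below may be only part of what the source reports. "The series", "measured", "known", "first", "only" and "open" are said of these compounds alone.

Measured so far in a functional assay on U-87MG ATCC cells for antiproliferative activity against U-87 MG (Homo sapiens), read by MTT assay, with a stated time of 48 h, tested at 50 uM; a higher number here means a weaker effect of the compound at the concentration tested, a lower number a stronger effect:
compound 1 `COc1cccc(-c2nc(SCC(=O)c3sc(-c4ccccc4)nc3C)[nH]c(=O)c2C#N)c1` gives 80.3%
compound 2 `Cc1nc(-c2ccccc2)sc1C(=O)CSc1nc(-c2ccc(Cl)cc2)c(C#N)c(=O)[nH]1` gives 63.4%
compound 3 `Cc1nc(-c2ccc(Cl)cc2)sc1C(=O)CSc1nc(-c2ccc(Cl)cc2)c(C#N)c(=O)[nH]1` gives 60%

Compound 4 `COc1cccc(-c2nc(SCC(=O)c3sc(-c4ccc(Cl)cc4)nc3C)[nH]c(=O)c2C#N)c1` has not been measured. It differs from compound 3 by 3-methoxyphenyl in place of 4-chlorophenyl on an aromatic carbon. The same change is made from compound 2 to compound 1, (3-methoxyphenyl in place of 4-chlorophenyl on an aromatic carbon), where it gives a number 16.9 percentage points higher from compound 2 to compound 1 (beyond the scatter). The cores of compound 3 and compound 2 differ by chloro in place of hydrogen on an aromatic carbon, a step of a number 3.4 percentage points lower from compound 2 to compound 3 (within the scatter). Since the place of the change is identical in both pairs, a step of similar size is expected, so compound 4 is estimated to show a number 17 percentage points higher from compound 3 to compound 4 (beyond the scatter) because compound 3 gives 60% and the earlier step was a number 16.9 percentage points higher from compound 2 to compound 1 (beyond the scatter). Going by the values given here, with only one pair showing the change, compound 4 is expected to come out near 77%, plausibly between 65% and 90%.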

Compound 4, a percentage reported as activity, at one concentration (the size of the read-out at that concentration, not a potency): 47.6%
Beside the measured number, compound 4's estimate is 29.4 percentage points above it; measured number below the stated range.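

In this assay, 3-methoxyphenyl in place of 4-chlorophenyl did not carry over from one core to the other, giving a number 12.4 percentage points lower from compound 3 to compound 4 (beyond the scatter) and pointing the opposite way from the earlier step: the same change on two cores in this assay, a number 16.9 percentage points higher (beyond the scatter) from compound 2 to compound 1 and a number 12.4 percentage points lower (beyond the scatter) from compound 3 to compound 4, 29.3 percentage points apart, beyond the scatter of two such steps
Chloro in place of hydrogen likewise depended on its partner group, giving a number 32.7 percentage points lower from compound 1 to compound 4 (beyond the scatter), unlike the earlier step: the same change on two cores in this assay, a number 3.4 percentage points lower (within the scatter) from compound 2 to compound 3 and a number 32.7 percentage points lower (beyond the scatter) from compound 1 to compound 4, 29.3 percentage points apart, beyond the scatter of two such steps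
Across these four compounds the two changes therefore do not act independently of each other, but this does not show why, nor how either change would behave on any further core.

The compounds shown leave open whether the shift depends on the methoxy group or on its place on the ring, which a 4-methoxyphenyl or a 3-chlorophenyl would separate. They also leave open whether fluoro in place of chloro would behave the same way.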